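This account rests on a few compounds, and the source may have more. Where it says the series, first, only, none or still open, it means among the compounds named here.

Measured in an ADME assay on Huh-7 cells (Homo sapiens) for cytotoxicity, read by a luciferase reporter and WST assay, with a stated time of 3 days; on this read-out lower numbers stand for higher toxicity in this test and higher numbers for lower toxicity in this test:
Compound 1 `Cc1ccc(NC(=O)c2c(NO)cc(-c3ccccc3)oc2=O)cc1`: > 20000 nM
Compound 2 `Cc1ccc(NC(=O)c2c(NO)cc(-c3ccc(Cl)cc3)oc2=O)cc1`: > 20000 nM
Compound 3 `COc1ccc(-c2cc(NO)c(C(=O)Nc3ccc(C)cc3)c(=O)o2)cc1`: > 20000 nM

Each of these entries is a limit and not a number. Compound 2 therefore has no exact place on the scale, and it shares its position with the other two compounds: the limit of > 20000 nM in this assay, at which 3 of the 3 values shown sit.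

Compound 4 `CNC(=O)c1c(NO)cc(-c2ccc(Cl)cc2)oc1=O` differs from compound 2 as follows: methyl in place of 4-methylphenyl on an amide-type nitrogen.

The measured steps are a step that the two limits leave unreadable from compound 1 to compound 2, a step that the two limits leave unreadable from compound 1 to compound 3 and a step that the two limits leave unreadable from compound 2 to compound 3. They exchange hydrogen, chloro and methoxy on an aromatic carbon, so none of them tests a change on the amide-type nitrogen, and none has a readable size.

With compound 2 giving the limit > 20000 nM, no step beyond the usual scatter is expected in this assay, and no direction can be named. The expected result is a step that the limit leaves unreadable from compound 2 to compound 4. The estimated value for compound 4 is 25000 nM, with an expected range of 12000 nM to 50000 nM.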

Compound 4, half-maximal cytotoxic concentration: > 20000 nM
Compound 4: no number, only a limit; the forecaster's own chance of this, stated with the estimate: 85%; the middle value is on the limit's open side.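

Among these compounds, compound 2 and compound 4 are both limits and not numbers, so swapping 4-methylphenyl for methyl on the amide-type nitrogen gives no step of readable size. The compounds shown leave open at what concentration, if any, each would become toxic to these cells.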